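Chloro for methyl on the alkynyl phenyl of compound 2

The compounds below may be only part of what the source reports. "The series", "measured", "known", "first", "only" and "open" are said of these compounds alone.

Compound 2 `Cc1cccc(C#Cc2ccc3c(n2)CCN(C(C)C)C3=O)c1` holds the lower of the two numbers obtained so far in a functional assay on HEK293 cells for negative allosteric modulation of metabotropic glutamate receptor 5 (Homo sapiens), read by FLIPR and calcium flux; on this read-out lower numbers stand for stronger inhibition and higher numbers for weaker inhibition: compound 2 gives 4.8 nM. Going by the values given here, its only measured neighbour is compound 1 `CC(C)N1CCc2nc(C#Cc3ccccc3)ccc2C1=O`, which in this assay gives 706 nM; the step of a 150-fold lower number from compound 1 to compound 2 (2.17 log units; beyond the scatter), a methyl in place of hydrogen on an aromatic carbon, is the one change that has been measured.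

Compound 3 `CC(C)N1CCc2nc(C#Cc3cccc(Cl)c3)ccc2C1=O` is the next variation at that same carbon: chloro in place of methyl on an aromatic carbon, on an aromatic carbon of a six-membered aromatic ring of carbon only, meta to a large group; cut one bond further out it reads 3-methylphenyl to 3-chlorophenyl. Among the compounds with values here, no measured step describes a methyl being exchanged for chloro. What the step from compound 1 to compound 2 shows is only that a single small substituent at this place moves this assay strongly, so the position is sensitive. A chloro substituent of the same size as methyl is expected to keep most of that gain, with a step of a 1.5-fold higher number from compound 2 to compound 3 (0.16 log units; within the scatter), within or near the scatter.

Compound 3 is therefore estimated at 7 nM in this assay, in the range 2 nM to 25 nM.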

Compound 3, half-maximal inhibitory concentration: 5.7 nM
Beside the measured number, compound 3's estimate is 1.2-fold (0.09 log units) above it; the range from low to high includes it.
By their numbers in this assay, from the lowest: compounds 2 and 3 (each within the scatter of the next); then compound 1.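

In this assay, chloro in place of methyl gives a 1.2-fold higher number from compound 2 to compound 3 (0.07 log units; within the scatter), so on this read-out the compounds shown do not separate the two substituents at this aromatic carbon. Chloro in place of hydrogen gives a 120-fold lower number from compound 1 to compound 3 (2.09 log units; beyond the scatter), a second large step at the same place alongside a 150-fold lower number from compound 1 to compound 2 (2.17 log units; beyond the scatter); the gain over compound 1 is therefore not confined to methyl but appears with both substituents shown. No measured information bears on why methyl and chloro give matching results here.

The compounds shown leave open whether the gain extends to other groups at this carbon, such as methoxy, trifluoromethyl, nitrile or an amine. They also leave open whether methyl or chloro on another carbon of the phenyl ring would move the read-out to a similar extent, so the sensitivity seen so far applies only to the 3-methylphenyl and 3-chlorophenyl compounds and their unsubstituted phenyl neighbour.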